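The source may hold more compounds than are shown below. What is called first, only, known or untested is meant among the compounds shown, and "the series" means these compounds.

In a functional assay on MCF7 cells (Homo sapiens) for inhibition, read by MTT assay, with a stated time of 72 h (a higher number here means a weaker inhibitor, a lower number a stronger inhibitor), compound 3 `COc1cc(OC)c(OC)cc1/C=C/C(=O)c1ccc(F)cc1` gives 30000 nM. Compound 1 `COc1cc(OC)c(OC)cc1/C=C/C(=O)c1ccc(Cl)cc1` gives 29500 nM, and the gap between them, a 1.0-fold higher number from compound 1 to compound 3 (0.01 log units; within the scatter), lies within the scatter, so these two stand level. For compound 2 `COc1cc(OC)c(OC)cc1/C=C/C(=O)c1ccc(-c2c[nH]cn2)cc1` the assay reports only a limit, > 150000 nM.

Compound 4 `COc1cc(OC)c(OC)cc1/C=C/C(=O)c1ccc([N+](=O)[O-])cc1` carries nitro in place of fluoro on an aromatic carbon, para to a large group (nitro in place of fluoro on an aromatic carbon). Two kinds of measured step bear on this change. Exchanging chloro for fluoro at this same place made no difference beyond the scatter, as a 1.0-fold higher number from compound 1 to compound 3 (0.01 log units; within the scatter) shows. Placing 1H-imidazol-4-yl there is the only change that moved the number beyond the scatter, seen as an at least 5.0-fold higher number from compound 1 to compound 2 (0.70 log units; beyond the scatter) and, in reverse, as an at least 5.0-fold lower number from compound 2 to compound 3 (0.69 log units; beyond the scatter). Both of these are sizes set by a limit. Nitro, like fluoro and chloro, brings no ring, so the closer guide is the flat step between compound 1 and compound 3, although three compounds are a thin basis.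

No step beyond the scatter is therefore expected in this assay, and the estimated step is a 1.2-fold lower number from compound 3 to compound 4 (0.08 log units; within the scatter). The estimate for compound 4 is 25000 nM, with an expected range from 8000 nM to 80000 nM.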

Compound 4, half-maximal inhibitory concentration: > 150000 nM
Compound 4 was reported as a limit; the forecaster's own chance of this, stated with the estimate: 10%; middle value at least 6.0-fold (0.77 log units) from the limit.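

In this assay, nitro in place of fluoro gives an at least 5.0-fold higher number from compound 3 to compound 4 (0.69 log units; beyond the scatter), and nitro in place of chloro gives an at least 5.0-fold higher number from compound 1 to compound 4 (0.70 log units; beyond the scatter), so the level exchange of chloro and fluoro does not extend to every group at this place. Before this result, 1H-imidazol-4-yl was the only group that had moved the number beyond the scatter, and nitro now shows that a group with no ring can also weaken the compound here. Both new sizes are only minimum sizes, and the step between compound 2 and compound 4 cannot be read, so these two groups cannot be ranked against each other: the limit of > 150000 nM in this assay, at which 2 of the 4 values shown sit.

As far as these compounds go, with only four groups at this place on the shared core, it remains open whether an amine or a nitrile on this aromatic carbon would stand level with compound 1 and compound 3 or would weaken the compound as nitro does. Also open, from the compounds shown here alone, is whether any group at this place can give a lower number than fluoro or chloro in this assay.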